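Ring contraction on the acylated amine of compound 2

The source may hold more compounds than are shown below. What is called first, only, known or untested is meant among the compounds shown, and "the series" means these compounds.

Compound 2 `CN1CCN(c2ccc(Nc3ncc4nc(Nc5ccc(F)cc5)n([C@@H]5CCCN(C(=O)CO)C5)c4n3)cc2)CC1` gives the lowest of the two numbers measured in a functional assay on HCC827 cells (Homo sapiens) for antiproliferative activity, read by MTT assay, with a stated time of 72 h (a lower number here means a stronger inhibitor, a higher number a weaker inhibitor), at 66 nM. Among the measured compounds shown here, its only measured neighbour is compound 1 `CN1CCN(c2ccc(Nc3ncc4nc(Nc5ccc(F)cc5)n([C@H]5CCNC5)c4n3)cc2)CC1`, which in this assay gives 1220 nM; the step of an 18-fold lower number from compound 1 to compound 2 (1.27 log units; beyond the scatter) exchanges both the ring size and the hydroxyacetyl group at once. Compound 3 `CN1CCN(c2ccc(Nc3ncc4nc(Nc5ccc(F)cc5)n([C@H]5CCN(C(=O)CO)C5)c4n3)cc2)CC1` takes back the smaller ring but keeps the hydroxyacetyl group: 1-((hydroxymethyl)carbonyl)pyrrolidin-3-yl in place of 1-((hydroxymethyl)carbonyl)piperidin-3-yl on an aromatic nitrogen. For the measured compounds named here, no measured step separates the ring size from the acylation, so the large step from compound 1 to compound 2 bears on compound 3 only in part, and the acyl group is kept. He therefore expects only a modest rise in the number for compound 3, a 1.8-fold higher number from compound 2 to compound 3 (0.26 log units; within the scatter), plausibly within the scatter. His estimate for compound 3 in this assay is 120 nM, with a range from 40 nM to 400 nM.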

Compound 3, half-maximal inhibitory concentration: 380 nM
For compound 3 the middle estimate is 3.2-fold (0.50 log units) below the measured one, and the stated range covers the measured number.
By their numbers in this assay, from the lowest: compound 2; then compound 3; then compound 1.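

Compound 3 pulls apart the two changes that were joined in the earlier step of an 18-fold lower number from compound 1 to compound 2 (1.27 log units; beyond the scatter). In this assay, with the five-membered ring held, placing the (hydroxymethyl)carbonyl group on the ring amine nitrogen gives a 3.2-fold lower number from compound 1 to compound 3 (0.51 log units; beyond the scatter), while with that acyl group held, the ring change gives a 5.8-fold higher number from compound 2 to compound 3 (0.76 log units; beyond the scatter), and both steps lie beyond the scatter, so at this position on the aromatic nitrogen the acylation and the ring size each register separately in the number. Nothing given here accounts for either step.

Going by these compounds, it remains open whether the (hydroxymethyl)carbonyl group would give a similar step on the piperidin-3-yl ring itself. Also unsettled is how a plain acetyl group, lacking the hydroxyl, or a seven-membered ring would compare with compound 2 at this position.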